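From methanesulfonamido to (cyclobutylcarbonyl)oxy: working notes

The source may hold more compounds than are shown below. What is called first, only, known or untested is meant among the compounds shown, and "the series" means these compounds.

- compound 1 `O=c1cc(N2CCN(CC3CCC(OS(=O)(=O)c4cccnc4)CC3)CC2)sc2c([N+](=O)[O-])cc(C(F)(F)F)cc12`: > 64 ug/mL (a limit)
- compound 2 `CS(=O)(=O)NC1CCC(CN2CCN(c3cc(=O)c4cc(C(F)(F)F)cc([N+](=O)[O-])c4s3)CC2)CC1`: 48.5 ug/mL

For the measured compounds named here, in an ADME assay on Vero cells (Chlorocebus sabaeus) for cytotoxicity, read by MTT assay, with a stated time of 48 h (a higher number here means a weaker inhibitor, a lower number a stronger inhibitor), compound 2 gives 48.5 ug/mL, the only actual number so far. The other entry, compound 1 at > 64 ug/mL, is a limit and not a number.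

Next in line is compound 3 `O=C(OC1CCC(CN2CCN(c3cc(=O)c4cc(C(F)(F)F)cc([N+](=O)[O-])c4s3)CC2)CC1)C1CCC1`, which carries (cyclobutylcarbonyl)oxy in place of methanesulfonamido on a saturated ring carbon. The shared core and the rest of the molecule stay as in compound 2.

Going by the values given here, one measured step bears on this change, as it also swaps the group on a saturated ring carbon: an at least 1.3-fold lower number from compound 1 to compound 2 (0.12 log units; that floor lies within the scatter). Among the compounds with values here, that step starts from a limit, so it gives only a floor, and no measured step yet shows a group at this carbon moving the number beyond the scatter. Neither group in that step is the incoming one, so the evidence is thin. No step beyond the scatter is therefore expected in this assay, and no direction is favoured. The expected change is a 1.0-fold higher number from compound 2 to compound 3 (0.01 log units; within the scatter). For compound 3 the estimated value is 50 ug/mL, with an expected range of 24 ug/mL to 105 ug/mL.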

Compound 3, half-maximal inhibitory concentration: > 64 ug/mL
Compound 3: only a limit was reported; the forecaster's own chance of this, stated with the estimate: 30%; middle value at least 1.2-fold (0.10 log units) from the limit.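

In this assay, (cyclobutylcarbonyl)oxy in place of methanesulfonamido on the saturated ring carbon gives an at least 1.3-fold higher number from compound 2 to compound 3 (0.12 log units; that floor lies within the scatter), so this change again yields only a floor and not a measured size. What is new is that a second oxygen-linked group at this carbon, now one with a four-membered non-aromatic ring of carbon only and without sulfur, also ends in a limit, as the ((pyridin-3-yl)sulfonyl)oxy group of compound 1 does. The steps that join compound 1 and compound 3 cannot be read, and the series is capped at one shared ceiling, so the two oxygen-linked groups cannot be told apart: the limit of > 64 ug/mL in this assay, at which 2 of the 3 values shown sit.

How far compound 1 and compound 3 actually lie from compound 2 stays open, and no group at this carbon has yet been shown to move the number beyond the scatter. Also open, from the compounds shown here alone, is whether an amine, a carboxylic acid or a longer chain on this saturated ring carbon would give a number well clear of the one methanesulfonamido gives.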